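The source may hold more compounds than are shown below. What is called first, only, known or untested is meant among the compounds shown, and "the series" means these compounds.

Measured in an ADME assay on HepG2 cells (Homo sapiens) for cytotoxicity, read by neutral red uptake, with a stated time of 4 days; on this read-out higher numbers stand for lower toxicity in this test and lower numbers for higher toxicity in this test:
Compound 1 `Nc1ncnc2c1ncn2[C@H]1CO[C@@H](CO)O1`: > 100000 nM, a limit
Compound 2 `COc1ncnc2c1ncn2[C@H]1CO[C@@H](CO)O1`: > 100000 nM, a limit

In this assay compound 2 gives > 100000 nM, which is a limit and not a number. It has no company above or below it on the numbers shown: the limit of > 100000 nM in this assay, at which 2 of the 2 values shown sit. Compound 3 `OC[C@@H]1OC[C@H](n2cnc3c(NC4CC4)ncnc32)O1` keeps the shared core and carries cyclopropylamino in place of methoxy on an aromatic carbon. Among the compounds with values here, only one measured step bears on this change, a step that the two limits leave unreadable from compound 1 to compound 2, which exchanges a group on the same aromatic carbon. That step has no readable size, so it offers nothing to carry over to the new group. Within the data shown here, the expectation therefore rests on the limit shared by the two measured compounds, and in this assay no step of definite size or direction is expected. Among the measured compounds shown here, a modest fall in the value cannot be ruled out, since no cyclopropylamino compound has been measured here. The expected change is a number no higher from compound 2 to compound 3 (the limit leaves the size open). For compound 3 the estimated value is 100000 nM, with an expected range from 30000 nM to 200000 nM.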

Compound 3, half-maximal cytotoxic concentration: > 100000 nM
Compound 3 was reported as a limit; the forecaster's own chance of this, stated with the estimate: 65%; the middle value sits exactly at the limit.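

In this assay compound 3 gives > 100000 nM and this is a limit, not a number. No new step can be read among compound 1, compound 2 and compound 3, which all sit together: the limit of > 100000 nM in this assay, at which 3 of the 3 values shown sit. The compounds shown leave open how far each lies beyond that limit, and so whether amino, methoxy or cyclopropylamino differ in this assay at all.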